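Cyclohexyl for Methyl on a Fused Thienopyrimidinone Scaffold

The compounds below may be only part of what the source reports. "The series", "measured", "known", "first", "only" and "open" are said of these compounds alone.

Compounds measured so far:
compound 1, `O=c1[nH]c(CN2CCCC2)nc2cc(-c3ccncc3)sc12` — 180 nM
compound 2, `Cc1nc2cc(-c3c[nH]nc3C)sc2c(=O)[nH]1` — 1500 nM

In an assay for inhibition of Rho-associated protein kinase 1 (Homo sapiens), read by TR-FRET, with stated times of 5 min and 2 h (on this read-out lower numbers stand for stronger inhibition and higher numbers for weaker inhibition), compound 1 gives 180 nM and compound 2 gives 1500 nM. Of the two numbers, compound 2 stands at the higher one, and its distance from compound 1 is beyond the scatter of this assay. The two compounds differ in more than one place, so nothing can be said about which change carries that gap.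

The step now followed goes from compound 2 to compound 3, `Cc1n[nH]cc1-c1cc2nc(C3CCCCC3)[nH]c(=O)c2s1`. It is a single change, (cyclohexyl in place of methyl on an aromatic carbon), a cyclohexyl in place of methyl on an aromatic carbon. For the measured compounds named here, no measured pair in this set isolates that change, so the direction of the step rests on expectation alone. A larger group at that position has not been tested on its own, and the account treats the outcome as open, with a moderate lowering of the number considered somewhat more likely than a rise. Compound 3 is expected to give 600 nM in this assay, with a range of 150 nM to 3000 nM, which would mean a step of a 2.5-fold lower number from compound 2 to compound 3 (0.40 log units; beyond the scatter).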

Compound 3, half-maximal inhibitory concentration: 940 nM
For compound 3 the middle estimate is 1.6-fold (0.19 log units) below the measured one; the range from low to high includes it.
By their numbers in this assay, from the lowest: compound 1; then compounds 3 and 2 (each within the scatter of the next).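

On the aromatic carbon between two ring nitrogen atoms, replacing methyl with cyclohexyl gives a 1.6-fold lower number from compound 2 to compound 3 (0.20 log units; within the scatter) in this assay. For the compounds shown here, this is the first measured pair to isolate a change at this position, and it shows that a group of 6 heavy atoms with a six-membered non-aromatic ring can stand in place of a single carbon without a number that can be told apart from that of compound 2. Nothing given here accounts for this result.

The compounds shown leave open whether the same holds for groups of another kind at this position, such as a phenyl ring, a primary amine or a carboxylic acid, since methyl and cyclohexyl both consist of carbon only and carry no hydrogen-bond donors or acceptors. Compound 1 has a different group at this position and also differs from compound 2 and compound 3 elsewhere, so whether its group would give a different number on their shared core remains unanswered.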